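Replacing fluoro with amino in compound 3

This account rests on a few compounds, and the source may have more. Where it says the series, first, only, none or still open, it means among the compounds named here.

Measured in a functional assay on MCF7 cells (Homo sapiens) for cytotoxicity, read by MTT assay, with a stated time of 96 h; on this read-out higher numbers stand for weaker inhibition and lower numbers for stronger inhibition:
- Compound 1 `COc1cc(C(=O)c2cn(-c3ccc(F)cc3)cc2-c2cccc([N+](=O)[O-])c2)cc(OC)c1OC` gives 440 nM
- Compound 2 `COc1cc(C(=O)c2cn(-c3ccc(F)cc3)cc2-c2ccc([N+](=O)[O-])cc2)cc(OC)c1OC` gives 240 nM
- Compound 3 `COc1cc(C(=O)c2cn(-c3ccc(F)cc3)cc2-c2cccc(N)c2)cc(OC)c1OC` gives 53 nM

Compound 3 holds the lowest number of the three, and both routes to it lie beyond the scatter: an 8.3-fold lower number from compound 1 to compound 3 (0.92 log units; beyond the scatter) and a 4.5-fold lower number from compound 2 to compound 3 (0.66 log units; beyond the scatter). The remaining step, a 1.8-fold lower number from compound 1 to compound 2 (0.26 log units; within the scatter), stays within the scatter.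

Compound 4 `COc1cc(C(=O)c2cn(-c3ccc(N)cc3)cc2-c2cccc(N)c2)cc(OC)c1OC` is still unmeasured. Its difference from compound 3 is amino in place of fluoro on an aromatic carbon, with the 4-fluorophenyl group becoming 4-aminophenyl.

Among the compounds with values here, no measured step touches this group. The nearest evidence is the step of an 8.3-fold lower number from compound 1 to compound 3 (0.92 log units; beyond the scatter), which also brings in an amino group, but there it replaces nitro, and at another place in the molecule. As far as these compounds go, it therefore offers only weak guidance, so no step beyond the scatter is expected, and the direction stays open. The expected change is a 1.2-fold lower number from compound 3 to compound 4 (0.07 log units; within the scatter), with wide uncertainty. For compound 4 the estimated value is 45 nM, with an expected range from 10 nM to 200 nM.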

Compound 4, half-maximal inhibitory concentration: 78 nM
For compound 4 the middle estimate is 1.7-fold (0.24 log units) below the measured one, within the range that was stated.
By their numbers in this assay, from the lowest: compounds 3 and 4 (each within the scatter of the next); then compounds 2 and 1 (each within the scatter of the next).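

In this assay, within the data shown here, the earlier compounds all carried fluoro at this place, so they said nothing about it; amino in place of fluoro now gives a 1.5-fold higher number from compound 3 to compound 4 (0.17 log units; within the scatter). The position on the 4-fluorophenyl group, para to a large group, therefore accepts this exchange without a change the assay can separate from scatter, even though amino brings a hydrogen-bond donor and acceptor that fluoro lacks in the count. No measurement at hand says what lies behind this outcome.

As far as these compounds go, what remains open is whether the position stays this accepting for other groups, such as hydroxyl, methoxy, a carboxylic acid or a longer chain. A single exchange also leaves open whether the same swap would behave alike with a nitro group on the other aryl ring.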